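The source may report more compounds than this note shows. Statements on the series, on what has been measured and on what is new or still open speak of the compounds shown alone.

Measured compounds and their results in a functional assay on HGC-27 cells (Homo sapiens) for inhibition, read by MTT assay, with a stated time of 72 h; a lower number here means a stronger inhibitor, a higher number a weaker inhibitor:
compound 1 `Cc1ccc(C(=O)Nc2ccc(CNC(=O)OCc3cccnc3)cc2)c(N2CCCC2)c1` gives 1870 nM
compound 2 `O=C(NCc1ccc(NC(=O)c2cc(Cl)ccc2N2CCCC2)cc1)OCc1cccnc1` gives 750 nM
compound 3 `Cc1ccc(N2CCCC2)c(C(=O)Nc2ccc(CNC(=O)OCc3cccnc3)cc2)c1` gives 1650 nM

Compound 3 has the second highest of the three numbers in this assay. Compound 1 sits within the scatter of it, so the two cannot be told apart; compound 2 sits clearly lower, that is, it is the stronger inhibitor of the pair.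

Compound 4 `O=C(NCc1ccc(NC(=O)c2cc(-c3ccccc3)ccc2N2CCCC2)cc1)OCc1cccnc1` has not yet been measured. It differs from compound 3 in one place: phenyl in place of methyl on an aromatic carbon. For the measured compounds named here, the only measured step that touches this position is a 2.2-fold higher number from compound 2 to compound 3 (0.34 log units; beyond the scatter), which shows that exchanging the group on that aromatic carbon moves the number only modestly. Going by the values given here, no measured compound carries a phenyl there, so the direction for compound 4 is open; the expected step is small, a 1.1-fold lower number from compound 3 to compound 4 (0.04 log units; within the scatter), possibly within the scatter.

Compound 4 is therefore estimated to give 1500 nM in this assay, with a range from 500 nM to 4500 nM.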

Compound 4, half-maximal inhibitory concentration: 4340 nM
The estimate for compound 4 lay 2.9-fold (0.46 log units) below the measured number; low and high end bracket the measured number.
By their numbers in this assay, from the lowest: compound 2; then compounds 3 and 1 (each within the scatter of the next); then compound 4.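

At this position, on the aromatic carbon para to the pyrrolidin-1-yl group, the phenyl ring settles the direction that was open: in this assay it gives a 2.6-fold higher number from compound 3 to compound 4 (0.42 log units; beyond the scatter) and a 5.8-fold higher number from compound 2 to compound 4 (0.76 log units; beyond the scatter), so it weakens inhibition against both methyl and chloro. Both steps lie beyond the scatter. The three groups now form an order among compounds that differ only here, with the number rising from chloro through methyl to phenyl, and the position therefore tolerates a six-carbon aromatic ring less well than either smaller group in this assay.

Nothing measured here gives a reason for this rise. As far as these compounds go, whether an amine, a carboxylic acid or a methoxy group on that carbon would bring the number below that of the chloro compound remains open.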